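Swapping a Piperidine for a Phenoxy Group on a Shared Core

The compounds below may be only part of what the source reports. "The series", "measured", "known", "first", "only" and "open" are said of these compounds alone.

Measured compounds:
- compound 1, `NC(N)=NC(=O)c1nc(Cl)c(N2CCCCC2)nc1N`: "not determined" (no result reported) in an assay for inhibition of acid-sensing ion channel 3 (Homo sapiens), read by patch clamp, tested at 1 uM; a higher number here means more inhibition at the concentration tested (going by the name of the read-out), a lower number less inhibition
- compound 2, `NC(N)=NC(=O)c1nc(Cl)c(OCc2ccc3ccccc3c2)nc1N`: 9%

Compound 1 is the starting point of this step. In this assay compound 1 gives "not determined" (no result reported), so there is no number to place it against. Within the data shown here, the only measured value here belongs to compound 2, which in this assay gives 9%, a small effect at the concentration tested.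

The unmeasured compound is compound 3, `NC(N)=NC(=O)c1nc(Cl)c(Oc2ccccc2)nc1N`. Compared with compound 1 it carries phenoxy in place of piperidin-1-yl on an aromatic carbon. Among the measured compounds shown here, with no result for compound 1 in this assay, no size or direction can be read for this step; the move from a piperidin-1-yl to a phenoxy group could raise, lower or leave the inhibition unchanged, and no step between measured compounds says which.

Resting on the single result available, compound 2 in this assay, compound 3 is expected to show weak inhibition, estimated at 10%, with a plausible range from -10% to 35%.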

Compound 3, a percentage reported as inhibition, at one concentration (the size of the read-out at that concentration, not a potency): 23%
Compound 3: middle estimate off by 13 percentage points, on the low side; low and high end bracket the measured number.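

Compound 1 gives "not determined" (no result reported) in this assay and compound 3 gives 23% there, so no step can be read between these two compounds. Still open, on these data alone, is whether phenoxy in place of piperidin-1-yl on the shared core raises, lowers or leaves unchanged the inhibition. Nothing available explains the result for compound 3.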